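Working notes: from ethoxycarbonyl to carboxy

The compounds below may be only part of what the source reports. "The series", "measured", "known", "first", "only" and "open" are said of these compounds alone.

In an ADME assay on MT4 cells (Homo sapiens) for cytotoxicity, read by MTT assay (on this read-out lower numbers stand for higher toxicity in this test and higher numbers for lower toxicity in this test), compound 1 (`COc1cccc2c(C(=O)/C=C(\O)C(=O)O)cn(Cc3ccc(F)cc3)c12`) stands at 82900 nM and compound 2 (`CCOC(=O)/C(O)=C/C(=O)c1cn(Cc2ccc(F)cc2)c2cc(OC)ccc12`) stands at 100000 nM on the same read-out. These two values lie within the scatter of each other, so compound 2 does not stand apart from compound 1. Going by the values given here, no step between measured compounds that differ in one place exists yet. Compound 3 (`COc1ccc2c(C(=O)/C=C(\O)C(=O)O)cn(Cc3ccc(F)cc3)c2c1`) follows from compound 2 by hydrogen in place of ethyl on an oxygen next to a carbonyl group in one place: hydrogen in place of ethyl on an oxygen next to a carbonyl group, so ethoxycarbonyl becomes carboxy. Compound 1 also carries carboxy, and its 82900 nM sits within the scatter of compound 2, so no shift beyond the scatter is expected in this assay in either direction. The expected step is a 1.3-fold lower number from compound 2 to compound 3 (0.10 log units; within the scatter) and it stays within the scatter. For compound 3 the estimated value is 80000 nM with an expected range from 35000 nM to 180000 nM for repeat measurements.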

Compound 3, half-maximal cytotoxic concentration: 66000 nM
Estimate against measurement, compound 3: 1.2-fold (0.08 log units) above; the measured number falls inside the stated range.
By their numbers in this assay, from the lowest: compounds 3, 1 and 2 (each within the scatter of the next).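

In this assay, going by these compounds alone, the exchange of ethoxycarbonyl for carboxy gives a 1.5-fold lower number from compound 2 to compound 3 (0.18 log units; within the scatter) and this is the first direct reading of that change, since compounds 1 and 2 differ in more than one place. At this position, hydrogen in place of ethyl on an oxygen next to a carbonyl group therefore gives two compounds that this read-out cannot tell apart, and the ethyl group is not needed for compound 3 to remain in the same range as compound 2. Nothing measured on these compounds bears on why the step is this small.

From the compounds shown here alone, whether a longer chain on that oxygen, or an amide in place of the carboxy group, would give a step beyond the scatter stays open. A single step on one core also leaves open whether the same change would read alike on other cores.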